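Cytotoxicity of a shared core toward a gastric cell line

The source may hold more compounds than are shown below. What is called first, only, known or untested is meant among the compounds shown, and "the series" means these compounds.

The study looks at how a series built on a shared core behaves in an ADME assay on GES1 cells (Homo sapiens) for inhibition, read by MTT assay, with a stated time of 72 h; on this read-out higher numbers stand for weaker inhibition and lower numbers for stronger inhibition. Compound 1 `CCCCCc1c(C)nc2nc(SCc3ccc(Cl)cc3)nn2c1Nc1cc(-c2ccccc2)[nH]n1` gives only a limit of the assay in this assay, > 50000 nM, and this limit is described further as the limit of > 50000 nM in this assay, at which 1 of the 3 values shown sits. Compound 2 `Cc1cc(Nc2cc(-c3ccc(Cl)cc3)[nH]n2)n2nc(SCc3ccc(Br)cc3)nc2n1` gives 28200 nM in this assay. Compound 3 `Cc1cc(Nc2cc(-c3ccccc3)[nH]n2)n2nc(SCCc3ccccc3)nc2n1` gives 37400 nM in this assay, and the numbers of compound 3 and compound 2 lie within the usual scatter of each other, so no order between the two can be read from them. Among the compounds with values here, no step between two measured compounds that differ in a single place is available here.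

The piece turns to compound 4 `COc1ccc(CSc2nc3nc(C)cc(Nc4cc(-c5ccccc5)[nH]n4)n3n2)cc1`, which has not yet been measured in this assay. Its structure differs from compound 3 in one place: 4-methoxyphenyl in place of benzyl on a saturated chain carbon bound to a sulfur. Since no comparable step among the measured compounds is shown, there is no basis for expecting a change beyond the scatter in either direction. Compound 4 is therefore expected to give about 35000 nM in this assay, with a likely range from 15000 nM to 80000 nM. The expected step of a 1.1-fold lower number from compound 3 to compound 4 (0.03 log units; within the scatter) is estimated to stay within the scatter.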

Compound 4, half-maximal inhibitory concentration: 28200 nM
Estimate against measurement, compound 4: 1.2-fold (0.09 log units) above, within the range that was stated.
By their numbers in this assay, from the lowest: compounds 2, 4 and 3 (each within the scatter of the next). At a limit, above all of these: compound 1.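

The change of 4-methoxyphenyl in place of benzyl on a saturated chain carbon bound to a sulfur gives the series its first step in a single place in this assay: a 1.3-fold lower number from compound 3 to compound 4 (0.12 log units; within the scatter). At this position, then, going from phenethylsulfanyl to (4-methoxybenzyl)sulfanyl, with a hydrogen-bond acceptor entering through the oxygen, leaves no change that can be read from this assay, and the two compounds cannot be put in any order. Nothing shown here gives a measured property that would bear on this result.

This single step speaks for one pair and one position, so it cannot say how far the same place tolerates other changes, or whether the other places on the shared core behave alike. Going by these compounds, it remains open whether an amine or a carboxylic acid on the aromatic ring of this side chain, or a longer chain between that ring and the sulfur, would move the number beyond the scatter.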